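The source may report more compounds than this note shows. Statements on the series, on what has been measured and on what is new or still open speak of the compounds shown alone.

Compound 1 `Cn1c(-c2ccc(NC(=O)CCl)cc2)nc(-c2ccccc2)c1-c1ccccc1`: in a functional assay on MCF7 cells (Homo sapiens) for cytotoxicity, read by MTT assay, with a stated time of 24 h (a lower number here means a stronger inhibitor, a higher number a weaker inhibitor), compound 1 gives 42.6 ug/mL.
Compound 2 `Cn1c(-c2ccc(NC(=O)CSc3nc4ccccc4o3)cc2)nc(-c2ccccc2)c1-c1ccccc1`: in this assay compound 2 gives 11.2 ug/mL.
Compound 3 `CN(C)/C=C/N1CCN(CC(=O)Nc2ccc(-c3nc(-c4ccccc4)c(-c4ccccc4)n3C)cc2)CC1`: in this assay compound 3 gives 80 ug/mL.

Compound 3 has the highest number of the three. Against compound 1 the gap is a 1.9-fold higher number from compound 1 to compound 3 (0.27 log units; within the scatter), so these two cannot be told apart. Against compound 2 the gap is a 7.1-fold higher number from compound 2 to compound 3 (0.85 log units; beyond the scatter), which is a real difference.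

Compound 4 `Cc1ccc(CN2CCN(CC(=O)Nc3ccc(-c4nc(-c5ccccc5)c(-c5ccccc5)n4C)cc3)CC2)cc1` differs from compound 3 in one place: 4-methylbenzyl in place of 2-(dimethylamino)ethenyl on an amine nitrogen in a ring. Among the measured compounds shown here, no measured step touches this ring nitrogen. The steps of a 3.8-fold lower number from compound 1 to compound 2 (0.58 log units; beyond the scatter) and a 1.9-fold higher number from compound 1 to compound 3 (0.27 log units; within the scatter) both exchange the group on the chain carbon bound to the carbonyl, and they show that such exchanges can move the number either way, but they say nothing about a change on the amine nitrogen in the ring. For the measured compounds named here, with no step of the same kind, the expected outcome is a number close to that of compound 3, and the step of a 1.3-fold lower number from compound 3 to compound 4 (0.12 log units; within the scatter) is expected to stay within the scatter. Compound 4 is therefore estimated at 60 ug/mL, with a range from 25 ug/mL to 150 ug/mL.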

Compound 4, half-maximal inhibitory concentration: 80 ug/mL
For compound 4 the middle estimate is 1.3-fold (0.12 log units) below the measured one, and the stated range covers the measured number.
By their numbers in this assay, from the lowest: compound 2; then compounds 1, 3 and 4 (each within the scatter of the next).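

In this assay, 4-methylbenzyl in place of 2-(dimethylamino)ethenyl on the amine nitrogen in the ring gives no change at the digits printed from compound 3 to compound 4 (within the scatter). Among the compounds shown here, this is the first measured change at that ring nitrogen, and it shows that an all-carbon group with an aromatic ring and a smaller open-chain group holding a nitrogen and a double bond cannot be told apart in this assay. Nothing available explains why these two groups read alike.

As far as these compounds go, whether this position stays as unresponsive with other kinds of group remains open, for instance a plain hydrogen on the ring nitrogen, or a carboxylic acid carried on a short chain. From the compounds shown here alone, it is also open whether a change on the aromatic ring of the 4-methylbenzyl, such as a chlorine in place of the methyl, would move the number.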